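Carbamate to Dimethylpiperidine on the Shared Core

The source may report more compounds than this note shows. Statements on the series, on what has been measured and on what is new or still open speak of the compounds shown alone.

Of the compounds shown here, two built on one core have been measured in a functional assay on CHO cells for agonist activity at 5-hydroxytryptamine receptor 1D (Homo sapiens), read by GTPgammaS binding; a higher number here means that more compound is needed for the effect, a lower number that less compound is needed. Compound 1 `OC1(CNCc2ccccc2)CCN(CCCc2c[nH]c3ccc(-n4cnnc4)cc23)CC1` gives 2.2 nM. Within the data shown here, compound 2 `CC(C)(C)OC(=O)NCC1(O)CCN(CCCc2c[nH]c3ccc(-n4cnnc4)cc23)CC1` gives 9.7 nM, the highest of the two numbers so far; its nearest neighbour is compound 1, and the only measured step, a 4.4-fold higher number from compound 1 to compound 2 (0.64 log units; beyond the scatter), is the exchange of tert-butoxycarbonyl for benzyl on an amine nitrogen.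

Compound 3 `CC1(C)CCCN(CC2(O)CCN(CCCc3c[nH]c4ccc(-n5cnnc5)cc34)CC2)C1` has not yet been measured. 3,3-dimethylpiperidin-1-yl in place of (tert-butoxycarbonyl)amino on a saturated chain carbon bound to a saturated ring carbon The carbamate that entered in the measured step now leaves, and a ring amine takes its place on the same saturated chain carbon. Among the measured compounds shown here, only the step from compound 1 to compound 2 bears on this change, and it was modest. A modest fall in the number for compound 3 is expected because compound 1, which also carries a nitrogen without a carbonyl at this position, gave 2.2 nM. The expected step is a 2.8-fold lower number from compound 2 to compound 3 (0.44 log units; beyond the scatter). For compound 3 the estimated value in this assay is 3.5 nM, with a range from 1 nM to 12 nM.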

Compound 3, concentration for half-maximal effect: 0.9 nM
Estimate against measurement, compound 3: 3.9-fold (0.59 log units) above; measured number outside the range, below it.
By their numbers in this assay, from the lowest: compound 3; then compound 1; then compound 2.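

In this assay, this saturated chain carbon accepts a ring amine, and the exchange of the carbamate for 3,3-dimethylpiperidin-1-yl gives an 11-fold lower number from compound 2 to compound 3 (1.03 log units; beyond the scatter), the largest step seen so far. Among these compounds, the new group also outdoes the benzylamino group of the earlier compounds, with a 2.4-fold lower number from compound 1 to compound 3 (0.39 log units; beyond the scatter), so the lowest number of the series now belongs to a group with 0 hydrogen-bond donors, and a hydrogen on this nitrogen is not needed for a low number in this assay. Among these three compounds, the two whose nitrogen at this place carries no carbonyl both lie below the carbamate, and compound 3 goes further than the step from compound 2 back to the benzylamino group of compound 1 would have suggested.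

Nothing given here accounts for the size of these steps or says what lies behind them. The compounds shown leave open whether the ring or its two methyl groups carry the fall, a question that plain piperidin-1-yl or morpholin-4-yl at the same saturated chain carbon would address.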